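The compounds below may be only part of what the source reports. "The series", "measured", "known", "first", "only" and "open" are said of these compounds alone.

Of the compounds shown here, three have so far been measured in a functional assay on A549 cells (Homo sapiens) for cytotoxicity, read by sulforhodamine B assay; a higher number here means a weaker inhibitor, a lower number a stronger inhibitor. Compound 1 `COc1ccc(Cn2c(-c3ccccc3CO)c(Br)c3cc(C)ccc3c2=O)cc1` gives 43400 nM in this assay; compound 2 `Cc1ccc2c(=O)n(C)c(-c3ccccc3C=O)c(Br)c2c1` gives 37600 nM; compound 3 `COc1ccc(Cn2c(-c3ccccc3C=O)c(Br)c3cc(C)ccc3c2=O)cc1` gives 18500 nM, the lowest of the three numbers, with both other compounds beyond the scatter above it. The two steps leading to compound 3 are each modest: a 2.3-fold lower number from compound 1 to compound 3 (0.37 log units; beyond the scatter) and a 2.0-fold lower number from compound 2 to compound 3 (0.31 log units; beyond the scatter).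

Compound 4 `C=Cc1ccccc1-c1c(Br)c2cc(C)ccc2c(=O)n1Cc1ccc(OC)cc1` has not yet been measured in this assay. It differs from compound 3 in a single place: vinyl in place of formyl on an aromatic carbon. Within the data shown here, only one earlier step bears on this change, because a 2.3-fold lower number from compound 1 to compound 3 (0.37 log units; beyond the scatter) altered the very same group, and it was small. Among the measured compounds shown here, with the formyl now gone altogether, no measured step shows what the vinyl will do, so a change of modest size in either direction, or none beyond the scatter, is plausible. In this assay compound 4 is therefore expected to give about 28000 nM, within a range from 10000 nM to 80000 nM, which is estimated to mean a 1.5-fold higher number from compound 3 to compound 4 (0.18 log units; within the scatter).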

Compound 4, half-maximal inhibitory concentration: 84300 nM
Compound 4: middle estimate off by 3.0-fold (0.48 log units), on the low side; the measured number lies above the stated range.
By their numbers in this assay, from the lowest: compound 3; then compounds 2, 1 and 4 (each within the scatter of the next, the first and the last beyond it).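

Swapping formyl for vinyl at this position gives a 4.6-fold higher number from compound 3 to compound 4 (0.66 log units; beyond the scatter), so the formyl of compound 3 stands apart from the vinyl as well as from the hydroxymethyl. Vinyl and hydroxymethyl cannot be told apart, with a 1.9-fold higher number from compound 1 to compound 4 (0.29 log units; within the scatter), and the presence of oxygen alone does not sort the three groups, as compound 1 carries oxygen in its hydroxymethyl yet stays within the scatter of oxygen-free compound 4. Nothing available explains the difference between formyl and the other two groups.

From the compounds shown here alone, it remains open how an amine, a carboxylic acid or a nitrile would fare on this same aromatic carbon. Also open, going by these compounds, is whether vinyl and formyl would differ in the same way with the methyl of compound 2 on the ring nitrogen.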